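The source may report more compounds than this note shows. Statements on the series, on what has been measured and on what is new or still open speak of the compounds shown alone.

Of the compounds shown here, three built on one shared core have been tested in a functional assay on MV4-11 cells (Homo sapiens) for antiproliferative activity, with a stated time of 6 days, tested at 6.25 uM; a lower number here means a weaker effect, a higher number a stronger effect of the compound at the concentration tested. Compound 1 `CNC(=O)N1CCCc2ccc(NC(=O)c3cccc(-c4cn[nH]c4)c3)cc21` gives 77.7%. Compound 3 `CNC(=O)N1CCCc2ccc(NC(=O)c3cccc(-c4ccn(C(C)=O)n4)c3)cc21` gives 87.6%. For the measured compounds named here, the only single-point step among the measured compounds, 1-acetyl-1H-pyrazol-3-yl in place of 1H-pyrazol-4-yl, is a number 9.9 percentage points higher from compound 1 to compound 3 (within the scatter), which stays within the scatter. Compound 2 `CNC(=O)N1CCCc2ccc(NC(=O)c3ccc(-c4ccncc4)cc3)cc21` gives 88.7% in this assay; the number of compound 3 lies within the scatter of it, while the number of compound 1 lies beyond the scatter and lower.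

Compound 4 `CNC(=O)N1CCCc2ccc(NC(=O)c3ccc(-c4cnn(C(C)=O)c4)cc3)cc21` has not yet been measured. It differs from compound 2 in one place: 1-acetyl-1H-pyrazol-4-yl in place of pyridin-4-yl on an aromatic carbon. Going by the values given here, no measured pair repeats this exact change. The nearest guide is a number 9.9 percentage points higher from compound 1 to compound 3 (within the scatter), where an acetyl-bearing pyrazolyl group also arrived and the step stayed within the scatter, and compound 3, which carries such a group, gives a number within the scatter of compound 2. So in this assay no step beyond the scatter is expected, a number 2.7 percentage points lower from compound 2 to compound 4 (within the scatter). Compound 4 is therefore estimated at 86%, with a range from 74% to 95%.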

Compound 4, a percentage reported as inhibition, at one concentration (the size of the read-out at that concentration, not a potency): 83.8%
Compound 4: the middle estimate sits 2.2 percentage points above what was measured; the measured number falls inside the stated range.
By their numbers in this assay, from the lowest: compounds 1, 4, 3 and 2 (each within the scatter of the next, the first and the last beyond it).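

Swapping pyridin-4-yl for 1-acetyl-1H-pyrazol-4-yl, on the aromatic carbon para to a large group, gives a number 4.9 percentage points lower from compound 2 to compound 4 (within the scatter) in this assay. The earlier step only exchanged one pyrazolyl group for another, whereas this one shows that a six-membered aromatic ring at this position can give way to a five-membered aromatic ring carrying an acetyl group, with more heavy atoms and more hydrogen-bond acceptors, and the change still stays within the scatter. No other kind of measurement accompanies these numbers, so the data offer no explanation for this result.

Going by these compounds, what the acetyl group contributes here remains open, and a plain 1H-pyrazol-4-yl at this position, paired with compound 4, would address that. Also open, on these data alone, is how far the tolerance extends, for instance to a carboxylic acid or an aminomethyl group in the same place.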